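The compounds below may be only part of what the source reports. "The series", "measured", "known", "first", "only" and "open" are said of these compounds alone.

Series notes: aromatic cyano substitution on the shared core

Compound 1 `CCC/C=C\C(=O)Nc1cc(Nc2nccc(-c3cn(C)c4ccccc34)n2)c(OC)cc1N(C)CCN(C)C` is the parent of this pair. In a functional assay on A549 cells (Homo sapiens) for antiproliferative activity, read by MTT assay, with a stated time of 72 h (on this read-out lower numbers stand for stronger inhibition and higher numbers for weaker inhibition), compound 1 gives 808 nM. Compound 2 `CCC/C=C\C(=O)Nc1cc(Nc2ncc(C#N)c(-c3cn(C)c4ccccc34)n2)c(OC)cc1N(C)CCN(C)C` carries one change relative to compound 1, (cyano in place of hydrogen on an aromatic carbon), and in this assay compound 2 gives 166 nM. The step is a 4.9-fold lower number from compound 1 to compound 2 (0.69 log units; beyond the scatter).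

Compound 3 `C=CC(=O)Nc1cc(Nc2nccc(-c3cn(C)c4ccc(F)cc34)n2)c(OC)cc1N(C)CCN(C)C` differs from compound 1 in more than one place; the difference between the two cores is not broken down here. In this assay compound 3 gives 329 nM, which places it between the other two measured numbers, with the gap to compound 2 within the scatter and the gap to compound 1 beyond it.

Compound 4 `C=CC(=O)Nc1cc(Nc2ncc(C#N)c(-c3cn(C)c4ccc(F)cc34)n2)c(OC)cc1N(C)CCN(C)C` is the cyano analogue built on the core of compound 3. The change is cyano in place of hydrogen on an aromatic carbon. For the measured compounds named here, it is the same kind of change as the one from compound 1 to compound 2: the leaving and entering groups and the ring position are described in the same words, and what differs around the place is only that the entering group stands ortho to a 5-fluoro-1-methyl-1H-indol-3-yl group rather than ortho to a 1-methyl-1H-indol-3-yl group. The change occurs twice among the compounds shown, once measured and once not.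

Going by the values given here, for compound 4 a step of about a 3.5-fold lower number from compound 3 to compound 4 (0.54 log units; beyond the scatter) in this assay is expected, somewhat smaller than the measured one, because the single precedent is a 4.9-fold lower number from compound 1 to compound 2 (0.69 log units; beyond the scatter) and one instance on a different core is a thin basis. The estimate for compound 4 in this assay is 95 nM, with a range from 40 nM to 250 nM.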

Compound 4, half-maximal inhibitory concentration: 9700 nM
For compound 4 the middle estimate is 100-fold (2.01 log units) below the measured one; the measured number lies above the stated range.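

On the core of compound 3, the same cyano in place of hydrogen on an aromatic carbon gives a step in this assay of a 29-fold higher number from compound 3 to compound 4 (1.47 log units; beyond the scatter). Set beside the earlier step, the change does not carry over from one core to the other in either direction or size: the same change on two cores in this assay, a 4.9-fold lower number (0.69 log units; beyond the scatter) from compound 1 to compound 2 and a 29-fold higher number (1.47 log units; beyond the scatter) from compound 3 to compound 4, 140-fold (2.16 log units) apart, beyond the scatter of two such steps This shows that, for these two pairs, the outcome of the change depends on the core; it does not show which difference between the cores goes with the reversal, as they differ in more than one place, including the 5-fluoro-1-methyl-1H-indol-3-yl group against the 1-methyl-1H-indol-3-yl group and the amide chain, and two pairs give no rule for the wider series.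

The compounds shown leave open whether a core carrying only one of those differences would follow the step to compound 2 or the step to compound 4. They also leave open how a chloro or a trifluoromethyl group in the same place, ortho to the indolyl group and para to a large group, would behave on either core.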